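Pyrazolyl-amino variation on the aminopyrimidine-carbonitrile series

The source may hold more compounds than are shown below. What is called first, only, known or untested is meant among the compounds shown, and "the series" means these compounds.

Of the compounds shown here, two have numbers so far. In an assay on isolated protein for binding affinity to Leucine-rich repeat serine/threonine-protein kinase 2 (Homo sapiens), read by TR-FRET and LanthaScreen, with a stated time of 2 h (on this read-out lower numbers stand for stronger inhibition and higher numbers for weaker inhibition), compound 1 `Cc1cn(C)nc1Nc1cc2c(c(N)n1)c(C#N)c(N1CCC[C@H]1C)n2C` gives 63 nM, the higher of the two numbers. For the measured compounds named here, compound 2 `C[C@@H]1CCCN1c1c(C#N)c2c(N)ncnc2n1C`, which carries no arylamino group on the shared core, gives 0.4 nM in this assay, a lower number lying well beyond the scatter from compound 1; no single-point step links these two, so only the two values themselves are noted.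

Compound 3 `C[C@@H]1CCCN1c1c(C#N)c2c(N)nc(Nc3cnn(C)c3)cc2n1C` has not been measured. It differs from compound 1 by 1-methyl-1H-pyrazol-4-yl in place of 1,4-dimethyl-1H-pyrazol-3-yl on a nitrogen on an aromatic ring. Going by the values given here, no measured pair shows this exact change, so nothing fixes its size or direction. The change removes one methyl from the pyrazole and moves the point of attachment; with the donor and acceptor counts unchanged, a small step is expected, and within the scatter is the most likely outcome.

The step from compound 1 to compound 3 is estimated at a 1.4-fold lower number from compound 1 to compound 3 (0.15 log units; within the scatter). Compound 3 is expected to give about 45 nM in this assay, in the range 12 nM to 180 nM.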

Compound 3, inhibition constant: 538 nM
Compound 3: the middle estimate sits 12-fold (1.08 log units) below what was measured; measured number above the stated range.
By their numbers in this assay, from the lowest: compound 2; then compound 1; then compound 3.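

In this assay, 1-methyl-1H-pyrazol-4-yl in place of 1,4-dimethyl-1H-pyrazol-3-yl on a nitrogen on an aromatic ring gives an 8.5-fold higher number from compound 1 to compound 3 (0.93 log units; beyond the scatter). For the compounds shown here, this is the first single-point step, and it shows that the number at this position responds to the choice of pyrazole, even though the hydrogen-bond donor and acceptor counts of the two groups are the same. No available measurement bears on the cause of this step.

Going by these compounds, the change removes one methyl and moves the point of attachment together, so the share of each remains open. A 1-methyl-1H-pyrazol-3-yl group on the same nitrogen would separate the two, since it keeps the attachment of compound 1 and lacks only the second methyl.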